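A few compounds are considered here, and "the series" means these few. Any claim that something is new, unique, unknown or untested is made for them only; others in the source may bear on it.

In a functional assay on NALM-6 cells (Homo sapiens) for cytotoxicity, with a stated time of 72 h (a lower number here means that less compound is needed, a higher number that more compound is needed for the effect), compound 1 `C=C[C@@](C)(/C=C/c1ccc(O)c(/C=C/C(=O)OCC)c1)CCC=C(C)C` gives 20900 nM. Compound 2 `C=C[C@@](C)(/C=C/c1ccc(O)c(/C=C/C(=O)OCc2ccccc2)c1)CCC=C(C)C` gives only a limit of the assay, > 43400 nM. As far as these compounds go, compound 3 `C=C[C@@](C)(/C=C/c1ccc(O)c(/C=C(\C)C(=O)OCC)c1)CCC=C(C)C` also gives only a limit, > 7500 nM, so its true place on the scale is unknown. Compound 4 `C=C[C@@](C)(/C=C/c1ccc(O)c(/C=C/c2ccc(F)cc2)c1)CCC=C(C)C` has not been measured, and the change leading to it is 2-(4-fluorophenyl)ethenyl in place of 2-(ethoxycarbonyl)prop-1-en-1-yl on an aromatic carbon. Going by the values given here, no measured step makes this exchange, and two bear on it only loosely: changing the ester gave an at least 2.0-fold higher number from compound 1 to compound 2 (0.31 log units; beyond the scatter), while adding a methyl to the double bond gave a step that the limit leaves unreadable from compound 1 to compound 3. The expected change is a step that the limit leaves unreadable from compound 3 to compound 4, a modest step whose direction remains uncertain. For compound 4 the estimated value is 15000 nM, with an expected range from 5000 nM to 45000 nM.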

Compound 4, half-maximal effective concentration: > 43400 nM
Compound 4 gave a limit, no number (the forecaster's own chance of this, stated with the estimate: 35%); middle value at least 2.8-fold (0.46 log units) away from the limit.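

In this assay, replacing the ethoxycarbonyl of compound 1 with 4-fluorophenyl on the double-bonded chain carbon gives an at least 2.0-fold higher number from compound 1 to compound 4 (0.31 log units; beyond the scatter). At this place, ortho to a hydroxy group, an aromatic ring on the double bond therefore gives no lower number than the ethyl ester does. The steps to compound 4 from compound 2 and from compound 3 cannot be read because each pair rests on limits: the limit of > 43400 nM in this assay, at which 2 of the 4 values shown sit.

As far as these compounds go, whether a carboxylic acid or an amine on this double bond would give a lower number than compound 1 stays open. From the compounds shown here alone, the true places of compound 2, compound 3 and compound 4 on the scale also stay open.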